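Ester variation at the cinnamate tail

This account rests on a few compounds, and the source may have more. Where it says the series, first, only, none or still open, it means among the compounds named here.

Measured compounds:
compound 1 `CCOC(=O)/C=C/c1ccc(NC(=O)C2(NC(=O)c3ccc4c(C5CCCC5)c(-c5ncc(Cl)cn5)n(C)c4c3)CCC2)cc1OCC` with 8.18 h
compound 2 `CCOc1cc(NC(=O)C2(NC(=O)c3ccc4c(C5CCCC5)c(-c5ncc(Cl)cn5)n(C)c4c3)CCC2)ccc1/C=C/C(=O)OCC(Cl)(Cl)Cl` with 1.3 h
compound 3 `CCOc1cc(NC(=O)C2(NC(=O)c3ccc4c(C5CCCC5)c(-c5ncc(Cl)cn5)n(C)c4c3)CCC2)ccc1/C=C/C(=O)OCc1ccccc1` with 2.23 h

In an ADME assay on a cell-free system (plasma, Rattus norvegicus) for pharmacokinetics (a lower number here means that the compound disappears faster, a higher number that the compound lasts longer), compound 1 gives the highest of the three numbers; compound 3 comes nearest and compound 2 lies furthest away. The compound now in question is compound 4 `CCOc1cc(NC(=O)C2(NC(=O)c3ccc4c(C5CCCC5)c(-c5ncc(Cl)cn5)n(C)c4c3)CCC2)ccc1/C=C/C(=O)OCC(=O)N1CCOCC1`, which differs from compound 1 only at the ester end: (morpholin-4-yl)carbonyl in place of methyl on a saturated chain carbon bound to an oxygen next to a carbonyl group.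

Both recorded steps from compound 1 touch the same place. Replacing that methyl by trichloromethyl gave a 6.3-fold lower number from compound 1 to compound 2 (0.80 log units; beyond the scatter), replacing it by phenyl gave a 3.7-fold lower number from compound 1 to compound 3 (0.56 log units; beyond the scatter). The difference between compounds 2 and 3 is a 1.7-fold higher number from compound 2 to compound 3 (0.23 log units; within the scatter). Within the data shown here, every change made at this position so far has therefore lowered the number in this assay by a modest but clear margin, and no change has left it level or raised it.

On that basis a lower number is expected for compound 4, a step of about a 3.3-fold lower number from compound 1 to compound 4 (0.51 log units; beyond the scatter) being estimated because of the pattern shown by a 6.3-fold lower number from compound 1 to compound 2 (0.80 log units; beyond the scatter) and a 3.7-fold lower number from compound 1 to compound 3 (0.56 log units; beyond the scatter). Compound 4 is thus estimated at 2.5 h, with a range from 0.8 h to 8 h.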

Compound 4, half-life: 1.83 h
Compound 4: middle estimate off by 1.4-fold (0.14 log units), on the high side; the measured number falls inside the stated range.
By their numbers in this assay, from the lowest: compounds 2, 4 and 3 (each within the scatter of the next); then compound 1.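

In this assay, a third replacement of the methyl on a saturated chain carbon bound to an oxygen next to a carbonyl group again lowers the number, with a 4.5-fold lower number from compound 1 to compound 4 (0.65 log units; beyond the scatter) for the (morpholin-4-yl)carbonyl group, so no compound shown goes against this direction. The larger group, with its six-membered non-aromatic ring, does not separate from the two earlier replacements, with a 1.2-fold lower number from compound 3 to compound 4 (0.09 log units; within the scatter) and a 1.4-fold higher number from compound 2 to compound 4 (0.15 log units; within the scatter), and trichloromethyl, phenyl and (morpholin-4-yl)carbonyl cannot be ranked against one another here. No measurement at hand bears on what lies behind the lower numbers.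

Open, on these data alone, is whether a longer chain such as propyl, or an amine such as dimethylaminomethyl, at this place would stay level with compound 1 or fall with the other three. Also open, as far as these compounds go, is what a carboxylic acid in place of the whole ester would give.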